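Methoxy for nitro on the aryl group of compound 2

The source may report more compounds than this note shows. Statements on the series, on what has been measured and on what is new or still open speak of the compounds shown alone.

Measured so far:
compound 1 `Oc1ccc(-c2nc3ccc(Br)cn3c2NC2CCCCC2)cc1` — 900 nM
compound 2 `Cc1ccc2nc(-c3ccc([N+](=O)[O-])cc3)c(NC3CCCCC3)n2c1` — > 30000 nM
compound 3 `Cc1ccc2nc(-c3ccncc3)c(NC3CCCCC3)n2c1` — 7700 nM

In an assay on S100 cells for inhibition of Polyunsaturated fatty acid 5-lipoxygenase (Homo sapiens), read by HPLC, with stated times of 15 min and 10 min (a lower number here means a stronger inhibitor, a higher number a weaker inhibitor), compound 1 gives 900 nM. Compound 3 reaches 7700 nM. For compound 2 only a limit of the assay is known, > 30000 nM, so that compound 2 stands at the limit of > 30000 nM in this assay, at which 1 of the 3 values shown sits, and its true value is not a number. The unmeasured compound 4 `COc1ccc(-c2nc3ccc(C)cn3c2NC2CCCCC2)cc1` differs from compound 2 by methoxy in place of nitro on an aromatic carbon. Within the data shown here, no step between two measured compounds is recorded, so the size of this change is open. Compound 1, which carries a hydroxy on the same ring, gives 900 nM, and compound 4 is therefore expected to gain by an at least 12-fold lower number from compound 2 to compound 4 (1.07 log units; beyond the scatter). Compound 4 is estimated at 2500 nM, between 600 nM and 12000 nM.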

Compound 4, half-maximal inhibitory concentration: 500 nM
Compound 4: the middle estimate sits 5.0-fold (0.70 log units) above what was measured; measured number outside the range, below it.
By their numbers in this assay, from the lowest: compounds 4 and 1 (each within the scatter of the next); then compound 3. At a limit, above all of these: compound 2.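

In this assay, methoxy in place of nitro on an aromatic carbon, para to a large group, gives an at least 60-fold lower number from compound 2 to compound 4 (1.77 log units; beyond the scatter), so the group at this position can change the result by a large margin. The size of that step is only a bound, as compound 2 sits at a limit and not a number: the limit of > 30000 nM in this assay, at which 1 of the 4 values shown sits.

With 4-methoxyphenyl in place of pyridin-4-yl, the step is a 15-fold lower number from compound 3 to compound 4 (1.19 log units; beyond the scatter), and here both ends are measured numbers.

The compounds shown leave open how an amine, a carboxylic acid or an ethoxy group at this position would compare with the methoxy of compound 4.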